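The source may hold more compounds than are shown below. What is called first, only, known or untested is meant among the compounds shown, and "the series" means these compounds.

Measured so far in a functional assay on DU-145 cells (Homo sapiens) for inhibition, read by trypan blue exclusion, with a stated time of 96 h; a higher number here means a weaker inhibitor of growth, a lower number a stronger inhibitor of growth:
- Compound 1 `Cc1ccc(S(=O)(=O)/C(=C/c2c(O)cc(O)cc2O)C(=O)c2ccc(Br)cc2)cc1`: > 100000 nM, a limit of the assay and not a number
- Compound 2 `Cc1ccc(S(=O)(=O)/C(=C/c2c[nH]c3ccc(Cl)cc23)C(=O)c2ccc(Br)cc2)cc1`: 10000 nM

Among the measured compounds shown here, compound 2 holds the only true number in this assay, so there is no spread of values to place it in. For the measured compounds named here, its one measured neighbour gives an at least 10-fold lower number from compound 1 to compound 2 (1.00 log units; beyond the scatter). That step swapped a whole group, 2,4,6-trihydroxyphenyl for 5-chloro-1H-indol-3-yl, so it does not show what the chloro alone contributes.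

Compound 3 `Cc1ccc(S(=O)(=O)/C(=C/c2c[nH]c3ccccc23)C(=O)c2ccc(Br)cc2)cc1` keeps the 1H-indol-3-yl group and loses only the chloro: hydrogen in place of chloro on an aromatic carbon. This is a far smaller edit than the one in an at least 10-fold lower number from compound 1 to compound 2 (1.00 log units; beyond the scatter), so a smaller step is expected, perhaps towards weaker inhibition. The estimated change is a 1.5-fold higher number from compound 2 to compound 3 (0.18 log units; within the scatter), and it may stay within the scatter. For compound 3 the expected value is 15000 nM, with an estimated range from 4000 nM to 60000 nM.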

Compound 3, concentration for 50% growth inhibition: 10000 nM
Compound 3: middle estimate off by 1.5-fold (0.18 log units), on the high side, within the range that was stated.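

Replacing the chloro on this aromatic carbon with hydrogen gives no change at the digits printed from compound 2 to compound 3 (within the scatter), so in this assay the chloro is not needed for the growth inhibition that compound 2 shows. The advantage over the 2,4,6-trihydroxyphenyl group therefore does not rest on the chloro, as the plain 1H-indol-3-yl group alone gives an at least 10-fold lower number from compound 1 to compound 3 (1.00 log units; beyond the scatter). Compound 1 stands at a limit of the assay and not a number, so the true size of that step stays unknown: the limit of > 100000 nM in this assay, at which 1 of the 3 values shown sits.

Going by these compounds, only chloro and hydrogen appear at this place, so it remains open whether a methoxy group, an amine or a carboxylic acid there would leave the number unchanged. On these data alone, it also remains open whether any group at this place could give stronger inhibition of growth.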